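Metabolic stability notes: phenoxy in place of trifluoromethyl

The source may report more compounds than this note shows. Statements on the series, on what has been measured and on what is new or still open speak of the compounds shown alone.

The series shares one core and varies the distal aryl group. Compound 1 `O=[N+]([O-])c1cn2c(n1)OC[C@@H](OCc1ccc(-c3ccccc3OCCCO)cc1)C2` carries a three-carbon hydroxyalkoxy chain; in an ADME assay on microsomes from liver (Homo sapiens) for metabolic stability, read by LC-MS, with a stated time of 1 h (on this read-out higher numbers stand for a more stable compound and lower numbers for a less stable compound), compound 1 gives 59%. Compound 2 `O=[N+]([O-])c1cn2c(n1)OC[C@@H](OCc1ccc(-c3cccc(OCc4ccccc4)c3)cc1)C2` carries a benzyloxy group, and in this assay compound 2 gives 64%. Compound 3 `O=[N+]([O-])c1cn2c(n1)OC[C@@H](OCc1ccc(-c3ccc(C(F)(F)F)cc3)cc1)C2` carries a trifluoromethyl group; in this assay compound 3 gives 60%. Compound 3 sits within the usual scatter of both other values, a single point from compound 1 and four points from compound 2, so the three measured compounds cannot be told apart on this read-out.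

Compound 4 `O=[N+]([O-])c1cn2c(n1)OC[C@@H](OCc1ccc(-c3ccc(Oc4ccccc4)cc3)cc1)C2` differs from compound 3 in one place: phenoxy in place of trifluoromethyl on an aromatic carbon. Within the data shown here, no pair of measured compounds differs in a single place, so no measured step bears directly on this change. The three measured values, spanning a hydroxyalkoxy chain, a benzyloxy group and a trifluoromethyl group, all fall inside one scatter band, and nothing in these numbers points to a move beyond that band for compound 4. The expectation is therefore a step of a number 5 percentage points lower from compound 3 to compound 4 (within the scatter), meaning no change beyond the scatter. Compound 4 is estimated at 55%, with a range from 40% to 70%.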

Compound 4, percent of the compound remaining: 22%
For compound 4 the middle estimate is 33 percentage points above the measured one, and the stated range ends above it.
By their numbers in this assay, from the lowest: compound 4; then compounds 1, 3 and 2 (each within the scatter of the next).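

Notes on the trifluoromethyl-to-phenoxy change: in this assay this exchange on an aromatic carbon, para to a large group, gives a number 38 percentage points lower from compound 3 to compound 4 (beyond the scatter) and is the first single-place step available in the series. It shows that this position is not indifferent to what it carries: one exchange, which brings in a six-membered aromatic ring of carbon only and one hydrogen-bond acceptor, moves the read-out well beyond the scatter. No measurement at hand accounts for the loss or shows which part of compound 4 is affected.

Still open, going by these compounds, is whether the loss belongs to the phenoxy group as a whole, to its ether oxygen or to its outer ring, and one step cannot separate these. A methoxy group, a benzyl group or a fluorine-bearing phenoxy group on the same aromatic carbon, each set against compound 3 and compound 4, would help to show which part of the group goes with the lower number, and an amine or a carboxylic acid there would test the position further.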